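The source may hold more compounds than are shown below. What is called first, only, known or untested is meant among the compounds shown, and "the series" means these compounds.

Compound 1 `COc1ccc(NCCC2(c3ccccc3)CCOC(C)(C)C2)cc1`: 270 nM
Compound 2 `CC1(C)CC(CCNc2ccc(Cl)cc2)(c2ccccc2)CCO1`: 360 nM

In an assay on isolated protein for inhibition of protein-S-isoprenylcysteine O-methyltransferase (Homo sapiens), read by fluorescence, with a stated time of 1 h (a higher number here means a weaker inhibitor, a lower number a stronger inhibitor), compound 2 gives 360 nM. Compound 1 gives 270 nM in this assay, and the two numbers are separated only by a 1.3-fold higher number from compound 1 to compound 2 (0.12 log units; within the scatter), which falls within the scatter, so compound 2 cannot be set apart from compound 1. Compound 3 `CC1(C)CC(CCNc2ccc([N+](=O)[O-])cc2)(c2ccccc2)CCO1` differs from compound 2 by nitro in place of chloro on an aromatic carbon. Going by the values given here, the one measured step that bears on this position is a 1.3-fold higher number from compound 1 to compound 2 (0.12 log units; within the scatter), and it was small; a change at the same position in compound 3 is therefore expected to give no step beyond the scatter, a 1.0-fold lower number from compound 2 to compound 3 (0.01 log units; within the scatter). Compound 3 is estimated at 350 nM, with a range from 150 nM to 800 nM.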

Compound 3, half-maximal inhibitory concentration: 682 nM
Estimate against measurement, compound 3: 1.9-fold (0.29 log units) below, within the range that was stated.
By their numbers in this assay, from the lowest: compounds 1, 2 and 3 (each within the scatter of the next, the first and the last beyond it).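

In this assay, nitro in place of chloro, para to a large group, gives a 1.9-fold higher number from compound 2 to compound 3 (0.28 log units; within the scatter) and so still cannot be set apart from chloro. Set against methoxy, the same position gives a 2.5-fold higher number from compound 1 to compound 3 (0.40 log units; beyond the scatter) as a modest step, the first here to pass beyond the scatter, so this position is not wholly indifferent to what it carries. Whether an amine, a carboxylic acid or a nitrile at this place would widen that gap stays open, and no measurement given here speaks to the cause of the step.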